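The compounds below may be only part of what the source reports. "The series", "measured", "known", "first", "only" and "open" are said of these compounds alone.

In an ADME assay on HOS cells (Homo sapiens) for cytotoxicity (on this read-out higher numbers stand for lower toxicity in this test and lower numbers for higher toxicity in this test), compound 3 (`CN(Cc1nc2cccc(C(=O)NCCCN)c2[nH]1)C1CCCc2cccnc21`) gives > 20000 nM, and this is a limit of the assay, not a number. It is the limit of > 20000 nM in this assay, at which 1 of the 3 values shown sits. Two relatives with a different substitution pattern have numbers: compound 1 (`CN(Cc1nc2ccccc2n1CCCCN)C1CCCc2cccnc21`) gives 2900 nM and compound 2 (`CN(Cc1nc2ccccc2n1CCCCCN)C1CCCc2cccnc21`) gives 4500 nM. Compound 4 (`CN(Cc1nc2cccc(CNCCN)c2[nH]1)C1CCCc2cccnc21`) remains unmeasured. It arises from compound 3 through one exchange, (((2-aminoethyl)amino)methyl in place of (3-aminopropyl)carbamoyl on an aromatic carbon), in which ((2-aminoethyl)amino)methyl replaces (3-aminopropyl)carbamoyl on an aromatic carbon.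

Among the measured compounds shown here, only one measured step exists in this small set, a 1.6-fold higher number from compound 1 to compound 2 (0.19 log units; within the scatter). For the measured compounds named here, that step concerns a saturated chain, not a group on an aromatic carbon, so it offers only weak guidance here, and no measured step tests the exchange itself. The one other hint is that neither compound 1 nor compound 2 carries the carbamoyl group, and compound 2 gives 4500 nM. Compound 4 loses that group too, so a move toward lower numbers in this assay is expected, although probably not all the way to that value. The expected step is an at least 1.6-fold lower number from compound 3 to compound 4 (0.22 log units; that floor lies within the scatter), an estimate that starts from a limit and is therefore loose. For compound 4 the estimated value is 12000 nM, with an expected range from 4000 nM to 30000 nM.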

Compound 4, half-maximal cytotoxic concentration: > 20000 nM
Compound 4 ended at the assay's limit; the forecaster's own chance of this, stated with the estimate: 30%; middle value at least 1.6-fold (0.22 log units) away from the limit.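

In this assay compound 4 gives > 20000 nM as a limit of the assay and not a number. Among the compounds shown here, compound 3 also stands at a limit, so no step between compound 3 and compound 4 can be read: the limit of > 20000 nM in this assay, at which 2 of the 4 values shown sit. The compounds shown leave open whether ((2-aminoethyl)amino)methyl in place of (3-aminopropyl)carbamoyl on an aromatic carbon changes the read-out at all.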